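The source may report more compounds than this note shows. Statements on the series, on what has been measured and on what is new or still open speak of the compounds shown alone.

Measured compounds:
compound 1 `O=CN1CCN(c2ccc(Cl)cc2)C1=S` gives 19200 nM
compound 2 `N#C/C(=C\N1CCN(C(=O)c2ccco2)C1=S)C(N)=O` gives 39800 nM
compound 3 `COc1cc(C(=O)N2CCN(C=O)C2=S)cc(OC)c1OC` gives 29400 nM

These three values come from a functional assay on MOLT-4 cells (Homo sapiens) for inhibition, read by sulforhodamine B assay, with a stated time of 48 h; on this read-out higher numbers stand for weaker inhibition of growth and lower numbers for stronger inhibition of growth. Compound 1 has the lowest of the three numbers. Its gap to compound 3 lies within the usual scatter, so no order between those two can be read from the data; compound 2 stands beyond the scatter from compound 1, with the higher number.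

The piece follows compound 1 to compound 4 `O=CN1CCN(c2ccc(Cl)c(Cl)c2)C1=S`. Going by the values given here, the single change is chloro in place of hydrogen on an aromatic carbon. Among the compounds with values here, no measured pair shows what such a change does here, so the size of the step is open. The step from compound 1 to compound 4 is expected to be small, a 1.4-fold lower number from compound 1 to compound 4 (0.14 log units; within the scatter), with no move beyond the scatter required. Compound 4 is expected to give 14000 nM, in a range from 5000 nM to 40000 nM.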

Compound 4, concentration for 50% growth inhibition: 22800 nM
Compound 4: the middle estimate sits 1.6-fold (0.21 log units) below what was measured, and the stated range covers the measured number.
By their numbers in this assay, from the lowest: compounds 1, 4, 3 and 2 (each within the scatter of the next, the first and the last beyond it).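

In this assay, chloro in place of hydrogen on an aromatic carbon, ortho to a chloro group, gives a 1.2-fold higher number from compound 1 to compound 4 (0.07 log units; within the scatter) and so stays within the scatter. This first measured pair shows that this carbon takes the added chloro with no readable shift in growth inhibition. No measured evidence here bears on why this is so.

From the compounds shown here alone, whether a methoxy group or an amine on this same carbon would also leave the number unmoved stays open. So does what happens if the chloro group already present in compound 1 is replaced.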